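Ester Exchange on a Hydroxy Analogue of a Lactone Series

A few compounds are considered here, and "the series" means these few. Any claim that something is new, unique, unknown or untested is made for them only; others in the source may bear on it.

Compound 1 `C=C1CC[C@H]2[C@@](C)(CC[C@@H](OC(C)=O)[C@@]2(C)C(=O)OC)[C@@H]1/C=C/C1=CCOC1=O` carries an acetoxy group and a methyl ester, and in a functional assay on NIH3T3 cells (Mus musculus) for inhibition, read by MTT assay, with a stated time of 72 h (on this read-out higher numbers stand for weaker inhibition and lower numbers for stronger inhibition), compound 1 gives 32300 nM. Compound 2 `C=C1CC[C@H]2[C@@](C)(CC[C@@H](OC(C)=O)[C@@]2(C)C(=O)OCc2ccccc2)[C@@H]1/C=C/C1=CCOC1=O` differs from it by phenyl in place of hydrogen on a saturated chain carbon bound to an oxygen next to a carbonyl group, and in this assay compound 2 gives 52700 nM, so that a 1.6-fold higher number from compound 1 to compound 2 (0.21 log units; within the scatter). Compound 3 `C=C1CC[C@H]2[C@@](C)(CC[C@@H](O)[C@@]2(C)C(=O)OC)[C@@H]1/C=C/C1=CCOC1=O` is the second core of the set, differing from compound 1 by hydrogen in place of acetyl on an oxygen on a saturated carbon; in this assay compound 3 gives 111000 nM, and a 3.4-fold higher number from compound 1 to compound 3 (0.54 log units; beyond the scatter), the highest number among the three measured compounds.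

Compound 4 `C=C1CC[C@H]2[C@@](C)(CC[C@@H](O)[C@@]2(C)C(=O)OCc2ccccc2)[C@@H]1/C=C/C1=CCOC1=O` is not yet measured. It stands to compound 3 as compound 2 stands to compound 1: phenyl in place of hydrogen on a saturated chain carbon bound to an oxygen next to a carbonyl group. The change is the same one seen between compound 1 and compound 2, made here on the hydroxy core instead of the acetoxy core. Going by the values given here, because a 1.6-fold higher number from compound 1 to compound 2 (0.21 log units; within the scatter), the only precedent for this change is a step that stays within the scatter, and the expectation for compound 4 is therefore a number close to that of compound 3, shifted in the same direction: the step expected is a 1.5-fold higher number from compound 3 to compound 4 (0.19 log units; within the scatter). On that basis compound 4 is estimated to give 170000 nM in this assay, with a likely range from 80000 nM to 360000 nM.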

Compound 4, half-maximal inhibitory concentration: 13600 nM
Beside the measured number, compound 4's estimate is 13-fold (1.10 log units) above it, and the stated range ends above it.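

In this assay, the exchange of methyl for benzyl on the ester does not carry over from the acetoxy core to the hydroxy core, where it gives an 8.2-fold lower number from compound 3 to compound 4 (0.91 log units; beyond the scatter), and the two steps part clearly: the same change on two cores in this assay, a 1.6-fold higher number (0.21 log units; within the scatter) from compound 1 to compound 2 and an 8.2-fold lower number (0.91 log units; beyond the scatter) from compound 3 to compound 4, 13-fold (1.12 log units) apart, beyond the scatter of two such steps Read the other way, the loss of the acetyl group also depends on the ester present, with a 3.9-fold lower number from compound 2 to compound 4 (0.59 log units; beyond the scatter) now opposing the earlier step: the same change on two cores in this assay, a 3.4-fold higher number (0.54 log units; beyond the scatter) from compound 1 to compound 3 and a 3.9-fold lower number (0.59 log units; beyond the scatter) from compound 2 to compound 4, 13-fold (1.12 log units) apart, beyond the scatter of two such steps These four compounds show that neither change has a fixed effect across the two cores, so the step seen on one core gives no safe estimate for the other, but this single set in one assay does not show why the effects differ or whether the same dependence holds for any other ester.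

As far as these compounds go, whether an ethyl ester, a longer chain on the ester oxygen or an amide in place of the ester would follow compound 4 or compound 3 remains open. From the compounds shown here alone, it is also open whether a propionyl group on the hydroxy oxygen would behave like the acetyl group of compound 2, or whether a substituted benzyl ester would keep the number of compound 4.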